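The source may hold more compounds than are shown below. What is called first, only, known or untested is meant among the compounds shown, and "the series" means these compounds.

Measured in a functional assay on K562 cells (Homo sapiens) for cytotoxicity, read by trypan blue exclusion, with a stated time of 96 h; on this read-out higher numbers stand for weaker inhibition and lower numbers for stronger inhibition:
- Compound 1 `COc1cc(OC)c(/C=C/S(=O)(=O)Nc2ccc(OC)c(O)c2)c(OC)c1`: 15 nM
- Compound 2 `COc1cc(OC)c(/C=C/S(=O)(=O)Nc2ccc(OC)c(NC(C)(C)C(=O)O)c2)c(OC)c1`: 5 nM
- Compound 3 `COc1cc(OC)c(/C=C/S(=O)(=O)Nc2ccc(OC)c(NC(C(=O)O)c3ccccc3)c2)c(OC)c1`: 300 nM

Lower numbers mean stronger inhibition here, so compound 3, at 300 nM, is the weakest of the three. Compound 4 `COc1cc(OC)c(/C=C/S(=O)(=O)Nc2ccc(OC)c(NC(C(=O)O)c3ccc(F)cc3)c2)c(OC)c1` differs from it by a single swap: fluoro in place of hydrogen on an aromatic carbon, para to a large group (fluoro in place of hydrogen on an aromatic carbon).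

Within the data shown here, no measured step makes this same swap, so the guidance is only indirect. The nearest evidence is a 20-fold higher number from compound 1 to compound 3 (1.30 log units; beyond the scatter) and a 60-fold higher number from compound 2 to compound 3 (1.78 log units; beyond the scatter). Both steps are large, which shows that the group carried on this nitrogen can matter. However, each of them exchanges a whole group, and a 3.0-fold lower number from compound 1 to compound 2 (0.48 log units; beyond the scatter) does the same on a more modest scale. Adding one fluoro to the phenyl is a much smaller edit. In this assay, the expected result is therefore little or no change beyond the scatter, and a 1.2-fold lower number from compound 3 to compound 4 (0.08 log units; within the scatter) is the estimated step. Compound 4 is expected at about 250 nM, within an estimated range of 80 nM to 800 nM.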

Compound 4, half-maximal inhibitory concentration: 20 nM
For compound 4 the middle estimate is 13-fold (1.10 log units) above the measured one; measured number outside the range, below it.
By their numbers in this assay, from the lowest: compound 2; then compounds 1 and 4 (each within the scatter of the next); then compound 3.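

In this assay, adding one fluoro on an aromatic carbon, para to a large group, proves to be no minor edit, since this single atom gives a large step (a 15-fold lower number from compound 3 to compound 4 (1.18 log units; beyond the scatter)). With it, the (carboxy(4-fluorophenyl)methyl)amino group lies within the scatter of the hydroxy group (a 1.3-fold higher number from compound 1 to compound 4 (0.12 log units; within the scatter)), while the 1-carboxy-1-methylethyl group on the same nitrogen still gives stronger inhibition (a 4.0-fold higher number from compound 2 to compound 4 (0.60 log units; beyond the scatter)). Nothing measured here accounts for the size of the fluoro step.

The compounds shown leave open whether this gain is specific to fluoro or would also come with chloro, methyl or methoxy on the same carbon. They also leave open how a fluoro would act elsewhere on that ring.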